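From bromo to methyl: one small swap

The compounds below may be only part of what the source reports. "The series", "measured", "known", "first", "only" and "open" are said of these compounds alone.

Measured in a functional assay on RAW264.7 cells (Mus musculus) for inhibition; on this read-out higher numbers stand for weaker inhibition and lower numbers for stronger inhibition
Compound 1 `Cc1ccc(S(=O)(=O)NC(=O)c2ccncc2)cc1` gives 9800 nM
Compound 2 `O=C(NS(=O)(=O)c1ccc(Br)cc1)c1ccccn1` gives 1900 nM

Of these two, compound 2 has the lower number and so the stronger inhibition, and the gap to compound 1 lies beyond the usual scatter of repeated measurements. Compound 3 `Cc1ccc(S(=O)(=O)NC(=O)c2ccccn2)cc1` is still unmeasured. It matches compound 2 except for one place, with methyl in place of bromo on an aromatic carbon. For the measured compounds named here, no measured pair shows this swap on its own, so its size is not known. Compound 1 also carries a methyl and gives 9800 nM, which leans the expectation towards weaker inhibition, although that compound differs elsewhere too. The expected step of a 1.7-fold higher number from compound 2 to compound 3 (0.23 log units; within the scatter) is a small rise in this assay, about the size of the scatter. For compound 3 the estimated value is 3200 nM with an expected range from 1200 nM to 9000 nM.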

Compound 3, half-maximal inhibitory concentration: 5900 nM
Estimate against measurement, compound 3: 1.8-fold (0.27 log units) below; measured number inside the range.
By their numbers in this assay, from the lowest: compound 2; then compounds 3 and 1 (each within the scatter of the next).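

In this assay methyl in place of bromo on this aromatic carbon, para to a large group, gives a 3.1-fold higher number from compound 2 to compound 3 (0.49 log units; beyond the scatter) and so puts a first size on this swap alone: here bromo gives stronger inhibition than methyl. The second comparison, pyridin-2-yl in place of pyridin-4-yl on a carbonyl carbon, gives a 1.7-fold lower number from compound 1 to compound 3 (0.22 log units; within the scatter) and leaves compound 1 and compound 3 indistinguishable, so this change has no readable effect in the methyl series. No supporting data are available to explain the difference between bromo and methyl.

The compounds shown leave open how chloro, methoxy or an amine at this position would compare with bromo. They also leave open whether bromo keeps its edge over methyl when pyridin-4-yl sits on the carbonyl carbon.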